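The compounds below may be only part of what the source reports. "The series", "measured", "known", "first", "only" and "open" are said of these compounds alone.

Working notes on the amide side chain of the series. In a functional assay on PC-3 cells (Homo sapiens) for antiproliferative activity, read by MTT assay, with a stated time of 24 h (on this read-out higher numbers stand for weaker inhibition and lower numbers for stronger inhibition), compound 1 (`CCn1c(C(=O)N[C@@H](C)CO)ccc1C(CC)(CC)c1ccc(OCS(=O)(=O)c2ccccc2)c(C)c1`) gives 9520 nM and compound 2 (`CCn1c(C(=O)NC(C)(C)CO)ccc1C(CC)(CC)c1ccc(OCS(=O)(=O)c2ccccc2)c(C)c1`) gives 9850 nM and these two values lie within the scatter of each other. The change from compound 2 to compound 3 (`CCn1c(C(=O)N[C@H](CO)C(C)C)ccc1C(CC)(CC)c1ccc(OCS(=O)(=O)c2ccccc2)c(C)c1`) is 1-(hydroxymethyl)-2-methylpropyl in place of 1-(hydroxymethyl)-1-methylethyl on an amide-type nitrogen and it places 1-(hydroxymethyl)-2-methylpropyl where 1-(hydroxymethyl)-1-methylethyl stood on an amide-type nitrogen. Going by the values given here, only one measured step bears on this position: a 1.0-fold higher number from compound 1 to compound 2 (0.01 log units; within the scatter) and it stays within the scatter. Among the compounds with values here, no measured compound carries the entering group, so the evidence is thin. No shift beyond the scatter is expected in this assay and the expected size is a 1.1-fold lower number from compound 2 to compound 3 (0.04 log units; within the scatter) (an estimate resting on that single step). Compound 3 is estimated at 9000 nM (expected range 4500 nM to 18000 nM).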

Compound 3, half-maximal inhibitory concentration: 7300 nM
The estimate for compound 3 lay 1.2-fold (0.09 log units) above the measured number; low and high end bracket the measured number.
By their numbers in this assay, from the lowest: compounds 3, 1 and 2 (each within the scatter of the next).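

In this assay, 1-(hydroxymethyl)-2-methylpropyl on the amide-type nitrogen gives no shift beyond the scatter relative to 1-(hydroxymethyl)-1-methylethyl (a 1.3-fold lower number from compound 2 to compound 3 (0.13 log units; within the scatter)). Isopropyl in place of methyl on the saturated chain carbon bound to the amide-type nitrogen also stays within the scatter (a 1.3-fold lower number from compound 1 to compound 3 (0.12 log units; within the scatter)), so a larger group at this carbon now joins the earlier pair with no step beyond the scatter among the three compounds. Nothing shown here offers an explanation for this result.

Open, on these data alone, is whether this level holds once the hydroxymethyl is replaced, for instance by a carboxylic acid or an amine, or when a benzyl or a longer chain stands at this carbon. As far as these compounds go, the opposite configuration at the defined stereocentre of compound 3 also remains open.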